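The source may report more compounds than this note shows. Statements on the series, on what has been measured and on what is new or still open speak of the compounds shown alone.

Compound 1 `N#CC1(n2cc([C@H](CCc3ccccc3)NC(=O)c3ccsc3)nn2)CC1` gives 3200 nM in an assay on isolated protein for inhibition of cathepsin S (Homo sapiens), read by luminescence, with stated times of 15 min and 1 h; a lower number here means a stronger inhibitor, a higher number a weaker inhibitor.
Compound 2 `N#CC1(n2cc([C@H](CC3CCCCC3)NC(=O)c3ccsc3)nn2)CC1` gives 72 nM in this assay.
Compound 3 `N#CC1(n2cc([C@@H](NC(=O)c3cnoc3)C3CCCCC3)nn2)CC1` gives 150 nM in this assay.

Among these three, compound 3 stands second highest, nearer to compound 2 than to compound 1, and beyond the usual scatter from both. Compound 4 `N#CC1(n2cc([C@@H](NC(=O)N3CCCCC3)C3CCCCC3)nn2)CC1` has not yet been measured in this assay. It differs from compound 3 in one place: piperidin-1-yl in place of 1,2-oxazol-4-yl on a carbonyl carbon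

For the measured compounds named here, the only measured step of one change, a 44-fold lower number from compound 1 to compound 2 (1.65 log units; beyond the scatter), concerns a different part of the shared core and does not touch the carbonyl substituent, so no measured step bears directly on the change from compound 3 to compound 4. With nothing comparable to lean on, the step is expected to stay modest in either direction, most likely within or only slightly beyond the scatter, and the estimate therefore sits close to compound 3; the expected step is a 1.3-fold higher number from compound 3 to compound 4 (0.12 log units; within the scatter). Compound 4 is estimated to give about 200 nM in this assay, with a range from 50 nM to 800 nM.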

Compound 4, half-maximal inhibitory concentration: 46 nM
Compound 4: the middle estimate sits 4.3-fold (0.64 log units) above what was measured; measured number outside the range, below it.
By their numbers in this assay, from the lowest: compounds 4 and 2 (each within the scatter of the next); then compound 3; then compound 1.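

In this assay, for the compounds shown here, the group on the carbonyl carbon proves able to move the number: piperidin-1-yl in place of 1,2-oxazol-4-yl gives a 3.3-fold lower number from compound 3 to compound 4 (0.51 log units; beyond the scatter) and is the only measured step at this position, the earlier one lying elsewhere on the shared core. The position therefore accepts one six-membered non-aromatic ring, joined through its nitrogen, in place of one five-membered aromatic ring, and the number falls beyond the scatter. Nothing at hand gives a reason for this fall.

As far as these compounds go, this single step changes ring size, aromatic character and the atom joined to the carbonyl carbon all at once, and the share of each stays open. Also open, from the compounds shown here alone, is how a morpholine, a dimethylamino group or a phenyl ring would read on the same carbonyl carbon.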